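Swapping Methylsulfanyl for Methylsulfonyl on a Fluoro Core

This account rests on a few compounds, and the source may have more. Where it says the series, first, only, none or still open, it means among the compounds named here.

Three compounds share a core and differ in the groups around it. In a functional assay on CHO cells for agonist activity at Alpha-2C adrenergic receptor (Homo sapiens) (a higher number here means a larger maximal response, a lower number a smaller maximal response), compound 1 `CSc1c(F)cccc1NCC1=NCCN1` gives 104%. Compound 3 `CSc1ccc(Cl)cc1NCC1=NCCN1` gives 92%, and compound 2 `CS(=O)(=O)c1ccc(Cl)cc1NCC1=NCCN1` gives 81%. The difference between the cores of compound 1 and compound 3 is not broken down here. From compound 3 to compound 2 one change is made, (methylsulfonyl in place of methylsulfanyl on an aromatic carbon), and it produced a number 11 percentage points lower from compound 3 to compound 2 (beyond the scatter). Compound 4 `CS(=O)(=O)c1c(F)cccc1NCC1=NCCN1` carries the same kind of change on the core of compound 1: methylsulfonyl in place of methylsulfanyl on an aromatic carbon. The surroundings differ, since in compound 2 the group sits para to a chloro group, while in compound 4 it sits ortho to a fluoro group. Compound 4 is expected to show a number 12 percentage points lower from compound 1 to compound 4 (beyond the scatter), an estimate resting on a number 11 percentage points lower from compound 3 to compound 2 (beyond the scatter). Compound 4 is thus estimated at 92%, likely between 80% and 104%.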

Compound 4, largest response reached (reported as maximum), in percent of the reference or control that the assay uses: 93%
Compound 4: middle estimate off by 1 percentage points, on the low side; the measured number falls inside the stated range.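

Replacing methylsulfanyl with methylsulfonyl on the core of compound 1 gave a number 11 percentage points lower from compound 1 to compound 4 (beyond the scatter) in this assay. Set beside the earlier step, the change carried over from one core to the other at much the same size: the same change on two cores in this assay, a number 11 percentage points lower (beyond the scatter) from compound 3 to compound 2 and a number 11 percentage points lower (beyond the scatter) from compound 1 to compound 4, 0 percentage points apart, within the scatter of two such steps. Going by these compounds alone, this rests on only two pairs of compounds in a single assay, so it shows agreement on these two cores, not a rule that would hold on other cores.

The compounds shown leave open how other groups in this place, such as an amine, a carboxylic acid or a longer chain, would alter the maximal response. They also leave open how much the fluoro and chloro groups themselves contribute.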